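Working notes: tolerated concentrations across the series

A few compounds are considered here, and "the series" means these few. Any claim that something is new, unique, unknown or untested is made for them only; others in the source may bear on it.

Measured so far:
compound 1 `CC1(C)[C@@H]2CC[C@@]1(C)/C(=N/NC(=O)c1cccs1)C2` — 1030000 nM
compound 2 `CCCC(=O)N/N=C1\C[C@H]2CC[C@]1(C)C2(C)C` — > 1190000 nM, a limit of the assay
compound 3 `CC(=O)N/N=C1\C[C@H]2CC[C@]1(C)C2(C)C` — "not determined" (no result reported)

Going by the values given here, in an ADME assay on MDCK cells (Canis lupus familiaris) for cytotoxicity, read by MTT assay, with a stated time of 48 h (a lower number here means that less compound is tolerated, a higher number that more compound is tolerated), compound 1 gives 1030000 nM, the only plain number in the set. For compound 2 the assay reports only a limit, > 1190000 nM. For compound 3 no result was reported. Among the compounds with values here, the single measured step that touches the carbonyl carbon is an at least 1.1-fold higher number from compound 1 to compound 2 (0.06 log units; that floor lies within the scatter); it rests on (the limit of > 1190000 nM in this assay, at which 1 of the 3 values shown sits), so it sets a floor rather than a size, and that floor lies within the scatter.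

Compound 4 `CC1(C)[C@@H]2CC[C@@]1(C)/C(=N/NC(=O)c1ccco1)C2` differs from compound 1 by furan-2-yl in place of thiophen-2-yl on a carbonyl carbon. Within the data shown here, the one step available does not show a shift beyond the scatter, and nothing else in this assay separates the compounds. Compound 4 is therefore expected to sit close to compound 1, with a 1.0-fold lower number from compound 1 to compound 4 (0.01 log units; within the scatter) as the expected step and no direction favoured. The estimate for compound 4 in this assay is 1000000 nM, expected between 500000 nM and 2000000 nM.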

Compound 4, half-maximal cytotoxic concentration: 1090000 nM
Beside the measured number, compound 4's estimate is 1.1-fold (0.04 log units) below it; the range from low to high includes it.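

In this assay, going by these compounds alone, the change to furan-2-yl in place of thiophen-2-yl on a carbonyl carbon gives the only step between two plain numbers, a 1.1-fold higher number from compound 1 to compound 4 (0.02 log units; within the scatter), so sulfur and oxygen in this five-membered aromatic ring are not separated here. The other new step, an at least 1.0-fold lower number from compound 2 to compound 4 (0.03 log units; that floor lies within the scatter), sets only a floor and gives no size for furan-2-yl in place of propyl: the limit of > 1190000 nM in this assay, at which 1 of the 4 values shown sits. Thiophen-2-yl, furan-2-yl and propyl on this carbonyl carbon therefore show no step beyond the scatter, although the steps involving propyl give floors only.

The compounds shown leave open whether a phenyl ring, an amine or a carboxylic acid on this carbonyl carbon would move the number beyond the scatter. Going by these compounds, how far the propyl compound's number lies past its limit also stays open.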